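Methoxy to hydroxy on the aryl ring of compound 3

A few compounds are considered here, and "the series" means these few. Any claim that something is new, unique, unknown or untested is made for them only; others in the source may bear on it.

Three compounds of the shared core carry a nitrile-bearing chain and have been read in a functional assay on SK-MEL-28 cells (Homo sapiens) for inhibition, read by sulforhodamine B assay, with a stated time of 48 h; on this read-out higher numbers stand for weaker inhibition of growth and lower numbers for stronger inhibition of growth. Compound 1 `COc1cc(C)cc(-c2c(-c3ccnc(-c4ccc(C(C)=O)cc4)c3)cnn2CC#N)c1` gives 7660 nM. Compound 2 `Cc1cc(O)cc(-c2nn(CC#N)cc2-c2ccnc(-c3ccc(Oc4ccccc4)cc3)c2)c1` gives 4920 nM. Compound 3 `COc1cc(C)cc(-c2nn(CC#N)cc2-c2ccnc(-c3ccc(N(C)C)cc3)c2)c1` gives 776 nM, the lowest of the three numbers; its gaps to compound 2 and to compound 1 both lie beyond the scatter, so among these three it is the strongest inhibitor of growth in this assay.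

Compound 4 `Cc1cc(O)cc(-c2nn(CC#N)cc2-c2ccnc(-c3ccc(N(C)C)cc3)c2)c1` has not been measured. Against compound 3 the change is hydrogen in place of methyl on an oxygen on an aromatic ring. Among the measured compounds shown here, no measured pair differs in this place alone; compound 2 carries the hydroxy but also a different group on the far aryl ring, so its value cannot be read as a guide to this single change. A step from compound 3 to compound 4 of a 1.4-fold higher number from compound 3 to compound 4 (0.15 log units; within the scatter) is expected, small and possibly within the scatter. Compound 4 is therefore estimated at 1100 nM, with a range from 400 nM to 3200 nM.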

Compound 4, concentration for 50% growth inhibition: 5220 nM
Beside the measured number, compound 4's estimate is 4.7-fold (0.68 log units) below it, and the stated range ends below it.
By their numbers in this assay, from the lowest: compound 3; then compounds 2, 4 and 1 (each within the scatter of the next).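

In this assay, the methoxy to hydroxy change can now be read on its own: hydrogen in place of methyl on the oxygen gives a 6.7-fold higher number from compound 3 to compound 4 (0.83 log units; beyond the scatter), with the dimethylamino group held constant. With the hydroxy held constant, dimethylamino in place of phenoxy on an aromatic carbon gives a 1.1-fold higher number from compound 2 to compound 4 (0.03 log units; within the scatter), so the two groups cannot be told apart in this setting, and the low number of compound 3 is tied, in this pair, to the methoxy. No measurement at hand accounts for the step at the oxygen.

Whether the same step appears with phenoxy or acetyl-bearing partners remains open, since no such pair is shown. Also open, on these data alone, is how an ethoxy group or an amine in place of the methoxy would read in this assay.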